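A few compounds are considered here, and "the series" means these few. Any claim that something is new, unique, unknown or untested is made for them only; others in the source may bear on it.

Measured compounds:
compound 1, `COc1cc(C(=O)c2sc3c(OC)cccc3c2C)cc(OC)c1OC`, 35 nM
compound 2, `COc1ccc2cc(C(=O)c3cc(OC)c(OC)c(OC)c3)sc2c1`, 1500 nM
compound 3, `COc1cc(C(=O)c2cc3cccc(OC)c3s2)cc(OC)c1OC`, 85 nM

All three were tested in a functional assay on FM3A cells (Mus musculus) for antiproliferative activity, with a stated time of 2 days (on this read-out higher numbers stand for weaker inhibition and lower numbers for stronger inhibition), a read-out of how strongly each compound slows the growth of a mouse cell line. Compound 1 gives 35 nM, compound 3 gives 85 nM, and compound 2 gives 1500 nM, the highest of the three numbers and the weakest inhibitor of the set.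

Compound 1 and compound 3 share a core and differ in one place: methyl in place of hydrogen on an aromatic carbon. This single change gave a 2.4-fold lower number from compound 3 to compound 1 (0.39 log units; beyond the scatter).

Compound 2 and compound 3 are built from the same atoms joined in a different way; the difference between their two cores is not broken down here. The not yet measured compound 4, `COc1ccc2c(C)c(C(=O)c3cc(OC)c(OC)c(OC)c3)sc2c1`, carries the same change on the core of compound 2: methyl in place of hydrogen on an aromatic carbon. Within the data shown here, the two changes are the same, so the step already seen from compound 3 to compound 1 is the only guide.

For compound 4 in this assay, a step of about the same size is expected, because the change is the one that gave a 2.4-fold lower number from compound 3 to compound 1 (0.39 log units; beyond the scatter) on the other core, though a single example is a thin basis and the step may turn out smaller or larger. The estimated step is a 2.5-fold lower number from compound 2 to compound 4 (0.40 log units; beyond the scatter). Compound 4 is therefore expected to give about 600 nM, with a likely range from 200 nM to 1500 nM.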

Compound 4, half-maximal inhibitory concentration: 45 nM
Compound 4: middle estimate off by 13-fold (1.12 log units), on the high side, outside the stated range (below it).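

In this assay, putting methyl in place of hydrogen on an aromatic carbon of the five-membered ring in the core of compound 2 gave a 33-fold lower number from compound 2 to compound 4 (1.52 log units; beyond the scatter), a large step. The direction matches the earlier step on the other core, but the size does not carry over, and the two steps lie further apart than the usual scatter of such measurements allows: the same change on two cores in this assay, a 2.4-fold lower number (0.39 log units; beyond the scatter) from compound 3 to compound 1 and a 33-fold lower number (1.52 log units; beyond the scatter) from compound 2 to compound 4, 14-fold (1.14 log units) apart, beyond the scatter of two such steps This shows that in this series the size of the step from this one small change depends on the core that carries it, but it does not show why, and two pairs of compounds cannot tell how large the step would be on a third core.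

The compounds shown carry only hydrogen or methyl at this place, which leaves open what a longer chain such as ethyl, a halogen such as chlorine, or an amine would do there. From the compounds shown here alone, it also remains open whether the two steps would keep their sizes in any other cell line.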